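The source may report more compounds than this note shows. Statements on the series, on what has been measured and on what is new or still open speak of the compounds shown alone.

Compound 1 `COc1cc2c(Oc3ccc(NC(=O)Nc4ccccc4Cl)cc3)ccnc2cc1OCCCCCCC(=O)NO` and compound 2 `COc1cc2c(Oc3ccc(NC(=O)Nc4ccc(OC(F)(F)F)cc4)cc3)ccnc2cc1OCCCCCCC(=O)NO` share one core and differ only in the group on an amide-type nitrogen. In a functional assay on MCF7 cells (Homo sapiens) for antiproliferative activity, read by MTT assay (on this read-out lower numbers stand for stronger inhibition and higher numbers for weaker inhibition), compound 1 gives 2780 nM and compound 2 gives 3200 nM, so compound 2 stands level with compound 1 within the scatter of repeated measurements.

Compound 3 `COc1cc2c(Oc3ccc(NC(=O)Nc4ccccc4C(F)(F)F)cc3)ccnc2cc1OCCCCCCC(=O)NO` keeps the shared core and changes that same group: 2-(trifluoromethyl)phenyl in place of 4-(trifluoromethoxy)phenyl on an amide-type nitrogen. Here 2-(trifluoromethyl)phenyl takes the place of 4-(trifluoromethoxy)phenyl, on the nitrogen whose other neighbours are the carbonyl carbon.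

Going by the values given here, only one measured step bears on this change: a 1.2-fold higher number from compound 1 to compound 2 (0.06 log units; within the scatter). That swap of 2-chlorophenyl for 4-(trifluoromethoxy)phenyl at the same place stayed within the scatter. Among the compounds with values here, it is a single step, and no measured compound yet carries 2-(trifluoromethyl)phenyl, so the expectation is modest: no change beyond the scatter in this assay. The expected step is a 1.1-fold lower number from compound 2 to compound 3 (0.04 log units; within the scatter). Compound 3 is estimated at 2900 nM, with an expected range from 1400 nM to 6000 nM.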

Compound 3, half-maximal inhibitory concentration: 1080 nM
Beside the measured number, compound 3's estimate is 2.7-fold (0.43 log units) above it; measured number outside the range, below it.
By their numbers in this assay, from the lowest: compound 3; then compounds 1 and 2 (each within the scatter of the next).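

In this assay, going by these compounds alone, the group on this amide-type nitrogen now proves able to move the number: 2-(trifluoromethyl)phenyl in place of 4-(trifluoromethoxy)phenyl gives a 3.0-fold lower number from compound 2 to compound 3 (0.47 log units; beyond the scatter), whereas the only earlier step at this place stayed within the scatter. The smaller exchange, trifluoromethyl in place of chloro on an aromatic carbon, gives a 2.6-fold lower number from compound 1 to compound 3 (0.41 log units; beyond the scatter), so changing that single group on the phenyl ring is enough to carry the number beyond the scatter. No supporting measurement is available to explain this difference.

With only three groups shown at this place, it remains open whether trifluoromethyl is special or whether a methyl, a nitrile or a methoxy group on the same ring would give a similar number. Going by these compounds, it also remains open whether an unsubstituted phenyl group would fall closer to compound 3 or to the pair of compound 1 and compound 2, which would show how much of the number depends on having any added group on the ring at all.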